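Dichlorobenzyl Change Tested on a Dimethylamino Analogue

This account rests on a few compounds, and the source may have more. Where it says the series, first, only, none or still open, it means among the compounds named here.

Compound 2 `CCN(CC)Cc1ccc2nc(NC(=O)N/N=C/c3cn(Cc4cccc(Cl)c4)c4ccccc34)sc2c1` carries a 3-chlorobenzyl group and a diethylamino chain. In a functional assay on MDA-MB-231 cells (Homo sapiens) for cytotoxicity, read by MTT assay, with a stated time of 72 h (on this read-out higher numbers stand for weaker inhibition and lower numbers for stronger inhibition), compound 2 gives 2050 nM. Compound 1 `CCN(CC)Cc1ccc2nc(NC(=O)N/N=C/c3cn(Cc4ccc(Cl)cc4Cl)c4ccccc34)sc2c1` differs from it only by 2,4-dichlorophenyl in place of 3-chlorophenyl on a saturated chain carbon bound to an aromatic nitrogen; in this assay compound 1 gives 3280 nM, and the step is a 1.6-fold higher number from compound 2 to compound 1 (0.20 log units; within the scatter). Compound 3 `CN(C)Cc1ccc2nc(NC(=O)N/N=C/c3cn(Cc4cccc(Cl)c4)c4ccccc34)sc2c1` keeps the 3-chlorobenzyl group, and in this assay compound 3 gives 1140 nM. Its core differs from the core of compound 2 by dimethylamino in place of diethylamino on a saturated chain carbon bound to an aromatic carbon, a step of a 1.8-fold lower number from compound 2 to compound 3 (0.25 log units; within the scatter). Compound 4 `CN(C)Cc1ccc2nc(NC(=O)N/N=C/c3cn(Cc4ccc(Cl)cc4Cl)c4ccccc34)sc2c1` has not yet been measured. It differs from compound 3 by 2,4-dichlorophenyl in place of 3-chlorophenyl on a saturated chain carbon bound to an aromatic nitrogen, the same change that separates compound 1 from compound 2, made at the same place, so this change appears in both pairs. Among the compounds with values here, a step of similar size is expected here, a 1.6-fold higher number from compound 3 to compound 4 (0.20 log units; within the scatter), because a 1.6-fold higher number from compound 2 to compound 1 (0.20 log units; within the scatter) is the only measured example of that change and both pairs share the same surroundings apart from the core. On that basis compound 4 is expected to give about 1800 nM in this assay, with a likely range from 900 nM to 3600 nM.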

Compound 4, half-maximal inhibitory concentration: 1410 nM
The estimate for compound 4 lay 1.3-fold (0.11 log units) above the measured number; the range from low to high includes it.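

In this assay, the change from 3-chlorobenzyl to 2,4-dichlorobenzyl gives a 1.2-fold higher number from compound 3 to compound 4 (0.09 log units; within the scatter), and the two measured steps of this change agree: the same change on two cores in this assay, a 1.6-fold higher number (0.20 log units; within the scatter) from compound 2 to compound 1 and a 1.2-fold higher number (0.09 log units; within the scatter) from compound 3 to compound 4, 1.3-fold (0.11 log units) apart, within the scatter of two such steps. The change from diethylamino to dimethylamino, read on the 2,4-dichlorobenzyl compounds, gives a 2.3-fold lower number from compound 1 to compound 4 (0.37 log units; beyond the scatter), and this step, although it lies beyond the scatter while its partner lies within it, also agrees with the earlier one: the same change on two cores in this assay, a 1.8-fold lower number (0.25 log units; within the scatter) from compound 2 to compound 3 and a 2.3-fold lower number (0.37 log units; beyond the scatter) from compound 1 to compound 4, 1.3-fold (0.11 log units) apart, within the scatter of two such steps. So each change carried over between the two cores in these four compounds, but two pairs per change cannot establish a general rule for the series, and the chlorine change, with both of its steps within the scatter, is not shown to alter the number at all.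

On these data alone, it remains open whether a ring amine such as morpholine or pyrrolidine in place of dimethylamino would fit the same picture. The same question applies to a benzyl group carrying fluorine or methoxy instead of chlorine.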